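The source may hold more compounds than are shown below. What is called first, only, known or untested is meant among the compounds shown, and "the series" means these compounds.

compound 1 (`CCC1C(=O)N(C)c2cnc(-n3ccc4cc(F)ccc43)nc2N1c1ccn(C)n1`): "not active" (no number reported)
compound 2 (`CCCCNS(=O)(=O)c1ccc(Nc2ncc3c(n2)N(c2ccn(C)n2)C(CC)C(=O)N3C)cc1`): 3750 nM
compound 3 (`CC[C@@H]1C(=O)N(C)c2cnc(Nc3ccc(S(=O)(=O)NCCO)cc3)nc2N1C1CCCC1`): 278 nM

In a functional assay on Huh-7 cells (Homo sapiens) for antiproliferative activity, read by CCK-8 assay, with a stated time of 72 h (on this read-out lower numbers stand for stronger inhibition of growth and higher numbers for weaker inhibition of growth), compound 1 is reported as "not active" (no number reported) and carries no number, so there is no measured growth inhibition from which to start. Compound 4 (`CCC1C(=O)N(C)c2cnc(-n3ccc4cc(C(=O)NC5CCCC5)ccc43)nc2N1c1ccn(C)n1`) keeps the core of compound 1 and exchanges one group, with cyclopentylcarbamoyl in place of fluoro on an aromatic carbon. Going by the values given here, no pair of measured compounds shows this kind of change, so the data give no size for it. The step expected in this assay runs toward stronger inhibition of growth, from no number to a weak but measurable one, although compound 4 may also remain without a number. Of the two compounds with numbers, the one closer in structure to compound 4 is compound 2 (3750 nM), and the expectation leans on that value. For compound 4 the estimated value is 5000 nM (expected range 1000 nM to 25000 nM).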

Compound 4, concentration for 50% growth inhibition: "not active" (no number reported)
Compound 4: no number reported; the estimate stays without a comparison.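

In this assay, going by these compounds alone, compound 1 gives "not active" (no number reported) and compound 4 gives "not active" (no number reported) so no step between them can be read. From the compounds shown here alone, whether cyclopentylcarbamoyl in place of fluoro on an aromatic carbon changes growth inhibition at all stays open. No further data bear on this result.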